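This account rests on a few compounds, and the source may have more. Where it says the series, first, only, none or still open, it means among the compounds named here.

Compound 1 `Cc1cccc(NNC(=O)c2cccc(NS(=O)(=O)c3cnc(O)nc3O)c2)c1`: > 20000 nM
Compound 2 `O=C(NNc1cccc(Cl)c1)c1cccc(NS(=O)(=O)c2cnc(O)nc2O)c1`: 7760 nM
Compound 3 `O=C(NNC(=O)c1ccccc1Cl)c1cccc(NS(=O)(=O)c2cnc(O)nc2O)c1`: 2360 nM

All three compounds were tested in a functional assay on MDA-MB-231 cells (Homo sapiens) for antiproliferative activity, read by MTT assay, with a stated time of 24 h; a lower number here means a stronger inhibitor, a higher number a weaker inhibitor. Compound 1 gives > 20000 nM, which is a limit of the assay and not a number. Of the two real numbers, the lower belongs to compound 3 with 2360 nM, and the nearest is compound 2 with 7760 nM.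

The next compound, compound 4 `O=C(NNC(=O)c1cccc(NS(=O)(=O)c2cnc(O)nc2O)c1)c1cccc(Cl)c1`, has the same atoms as compound 3, joined differently: 3-chlorophenyl in place of 2-chlorophenyl on a carbonyl carbon. Put simply, 3-chlorophenyl stands in place of 2-chlorophenyl on a carbonyl carbon.

For the measured compounds named here, no measured pair shows this swap alone. The closest guide is a 3.3-fold lower number from compound 2 to compound 3 (0.52 log units; beyond the scatter), but there (2-chlorophenyl)carbonyl replaces 3-chlorophenyl on an amine nitrogen, so much more changes than in the new swap. The other two steps, an at least 2.5-fold lower number from compound 1 to compound 2 (0.41 log units; beyond the scatter) and an at least 8.4-fold lower number from compound 1 to compound 3 (0.92 log units; beyond the scatter), start from a limit and involve different changes. Going by the values given here, they show only that single changes can shift the number modestly, and they give no direction for compound 4. No step beyond the scatter is therefore expected, and the estimate is a 1.2-fold higher number from compound 3 to compound 4 (0.07 log units; within the scatter). For compound 4 the estimated value is 2800 nM, with an expected range from 900 nM to 8500 nM.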

Compound 4, half-maximal inhibitory concentration: 3180 nM
Beside the measured number, compound 4's estimate is 1.1-fold (0.06 log units) below it; low and high end bracket the measured number.
By their numbers in this assay, from the lowest: compounds 3 and 4 (each within the scatter of the next); then compound 2. At a limit, above all of these: compound 1.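

In this assay, for the compounds shown here, 3-chlorophenyl in place of 2-chlorophenyl on a carbonyl carbon gives a 1.3-fold higher number from compound 3 to compound 4 (0.13 log units; within the scatter), so the two chlorophenyl groups cannot be told apart at this place, something no earlier pair could show. The lower number seen earlier for the (2-chlorophenyl)carbonyl group therefore does not depend on that one group: bringing in the (3-chlorophenyl)carbonyl group gives a 2.4-fold lower number from compound 2 to compound 4 (0.39 log units; beyond the scatter), a modest step in the same direction, and neither compound with a chlorophenylcarbonyl group goes against this. The same group in place of 3-methylphenyl on an amine nitrogen gives an at least 6.2-fold lower number from compound 1 to compound 4 (0.79 log units; beyond the scatter), a step that starts from a limit of the assay and not from a number: the limit of > 20000 nM in this assay, at which 1 of the 4 values shown sits.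

Going by these compounds, what stays open is whether the number at this carbonyl carbon would also hold with something other than chlorine on the ring, such as a methoxy group, a nitrile or a trifluoromethyl group, or with a plain phenyl ring. On these data alone, it is also open whether the two chlorophenyl groups would remain this close in cells other than those of this one assay.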